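Biaryl replacement in a cyclopropane-carboxamide series at GPR88

A few compounds are considered here, and "the series" means these few. Any claim that something is new, unique, unknown or untested is made for them only; others in the source may bear on it.

Measured so far:
- compound 1, `CC[C@H](C)[C@H](N)CN(C(=O)[C@@H]1C[C@H]1c1cccc(OC)c1)c1ccc(-c2ccccc2)cc1`: 3000 nM
- compound 2, `CC(C)C[C@H](N)CN(C(=O)[C@@H]1C[C@H]1c1ccccc1)c1ccc(-c2ccsc2)cc1`: 1200 nM

In a functional assay for agonist activity at G protein-coupled receptor 88 (Homo sapiens), read by HTRF and cAMP accumulation (on this read-out higher numbers stand for an effect only at larger amounts of compound and lower numbers for an effect already at smaller amounts), compound 2 gives 1200 nM, the lower of the two numbers obtained so far. Compound 1 gives 3000 nM in this assay; the gap between the two lies beyond the usual scatter, but the two structures differ in more than one place, so nothing can be drawn from it about any single group.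

Compound 3, `CC(C)C[C@H](N)CN(C(=O)[C@@H]1C[C@H]1c1ccccc1)c1ccc(-c2ccccc2Cl)cc1`, is not yet measured. It keeps the shared core of compound 2 and differs only in the biaryl terminus: 2-chlorophenyl in place of thiophen-3-yl on an aromatic carbon. Among the measured compounds shown here, no measured pair isolates this exchange. The expectation is a small step from compound 2 to compound 3, a 1.3-fold higher number from compound 2 to compound 3 (0.12 log units; within the scatter), within or close to the scatter and if anything toward a higher number. For compound 3 the estimate is 1600 nM, with a range of 500 nM to 5000 nM.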

Compound 3, half-maximal effective concentration: 3800 nM
For compound 3 the middle estimate is 2.4-fold (0.38 log units) below the measured one; the measured number falls inside the stated range.
By their numbers in this assay, from the lowest: compound 2; then compounds 1 and 3 (each within the scatter of the next).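

In this assay, among the compounds shown here, the biaryl terminus is the first position isolated by a single change: with the shared core held constant, 2-chlorophenyl in place of thiophen-3-yl, para to a large group, gives a 3.2-fold higher number from compound 2 to compound 3 (0.50 log units; beyond the scatter), a modest step. This position therefore responds to the exchange of its terminal ring, and of the two groups tried on this core, thiophen-3-yl gives the lower number. For the compounds shown here, nothing available explains the step, and the single exchange changes both the ring and the presence of chlorine, so the two cannot be separated.

Open, as far as these compounds go, is where an unsubstituted phenyl on the core of compound 2 would fall relative to compound 2 and compound 3. Also open, from the compounds shown here alone, is how a furan or pyridine ring would read at this position.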